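Sulfonamide series: removing the amine methyl in compound 2

This account rests on a few compounds, and the source may have more. Where it says the series, first, only, none or still open, it means among the compounds named here.

Of the compounds shown here, three have numbers so far. Compound 1 `CC(C)(C)c1ccc(CNCCCNS(=O)(=O)c2cc(C(F)(F)F)cc(C(F)(F)F)c2)cc1` gives 2300 nM in a functional assay on MIA PaCa-2 cells (Homo sapiens) for inhibition, read by MTT assay, with a stated time of 72 h; on this read-out lower numbers stand for stronger inhibition of growth and higher numbers for weaker inhibition of growth. Compound 3 `O=S(=O)(NCCCCCCNCc1ccc(Br)cc1)c1cc(C(F)(F)F)cc(C(F)(F)F)c1` gives 2970 nM in this assay. Compound 2 `CN(CCCNS(=O)(=O)c1cc(C(F)(F)F)cc(C(F)(F)F)c1)Cc1ccccc1` gives 33000 nM in this assay, the highest of the three numbers, beyond the scatter from both compound 1 and compound 3. Compound 2 is the only one of the three whose chain amine carries a methyl; compound 1 and compound 3 differ from it in more than one place, so no single step can be read between them.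

Compound 4 `COc1cccc(CNCCCNS(=O)(=O)c2cc(C(F)(F)F)cc(C(F)(F)F)c2)c1` has not been measured. It differs from compound 2 by (3-methoxybenzyl)amino in place of benzyl(methyl)amino on a saturated chain carbon, three bonds along the chain from a sulfonamide nitrogen. The methyl on the amine leaves and a methoxy group enters on the benzyl ring.

Expectation: since compound 1 with 2300 nM and compound 3 with 2970 nM both lack the amine methyl and sit well below compound 2, the step from compound 2 to compound 4 is expected to be downward and beyond the scatter, estimated at an 8.3-fold lower number from compound 2 to compound 4 (0.92 log units; beyond the scatter). From the compounds shown here alone, the methoxy contribution is unknown from the data. Compound 4 is estimated at 4000 nM, with a range from 1500 nM to 12000 nM.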

Compound 4, concentration for 50% growth inhibition: 3400 nM
Compound 4: the middle estimate sits 1.2-fold (0.07 log units) above what was measured; measured number inside the range.
By their numbers in this assay, from the lowest: compounds 1, 3 and 4 (each within the scatter of the next); then compound 2.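

In this assay the change at this saturated chain carbon gives a 9.7-fold lower number from compound 2 to compound 4 (0.99 log units; beyond the scatter) and so counts as a large drop in the number, even though two features change in that one place: the methyl on the amine leaves and a methoxy group enters on the benzyl ring. Within the compounds without the amine methyl, the aryl group on the saturated chain carbon bound to an amine nitrogen tolerates replacement, with 3-methoxyphenyl in place of 4-(tert-butyl)phenyl giving a 1.5-fold higher number from compound 1 to compound 4 (0.17 log units; within the scatter) and thus no readable difference between these two groups. Going by these compounds alone, compound 2 therefore remains the only compound apart from the others on this read-out, and no measurement at hand bears on the reason for that gap.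

From the compounds shown here alone, the step from benzyl(methyl)amino to (3-methoxybenzyl)amino cannot divide its size between loss of the methyl and gain of the methoxy group, so the share of each stays open. Also open, going by these compounds, is how the number responds to an ethyl group on the amine nitrogen, or to an amide carbonyl at that nitrogen, with the benzyl ring held constant.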